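The source may report more compounds than this note shows. Statements on the series, on what has been measured and on what is new or still open speak of the compounds shown alone.

Of the compounds shown here, three sharing one core have been measured in a functional assay for inhibition, with Homo sapiens as the target; on this read-out lower numbers stand for stronger inhibition and higher numbers for weaker inhibition. Compound 1 `c1ccc(-c2ccnc(Nc3cccc(OCCn4ccnc4)c3)n2)nc1` gives 400 nM. Compound 2 `c1cc(Nc2nccc(-c3cccs3)n2)cc(OCCn2ccnc2)c1` gives 100 nM, and compound 3 `c1cc(Nc2nccc(-c3ccco3)n2)cc(OCCn2ccnc2)c1` gives 200 nM. Among these three numbers compound 1 stands highest: the step of a 4.0-fold lower number from compound 1 to compound 2 (0.60 log units; beyond the scatter) lies beyond the scatter, whereas the step of a 2.0-fold lower number from compound 1 to compound 3 (0.30 log units; within the scatter) does not, so compound 1 and compound 3 cannot be ordered against each other.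

The unmeasured compound 4 `CCOC(=O)c1cccc(Nc2nccc(-c3ccccn3)n2)c1` differs from compound 1 in one place: ethoxycarbonyl in place of 2-(1H-imidazol-1-yl)ethoxy on an aromatic carbon. Going by the values given here, none of the measured steps bears on this change, since each of them alters the aryl group on the other side of the core, whereas the pyridin-2-yl of compound 1 is kept in compound 4. Among the compounds with values here, there is therefore no measured step from which a direction can be read, and the expectation rests on compound 1 alone, with wide uncertainty. Compound 4 is expected to give about 600 nM, between 150 nM and 3000 nM, which means an expected step of a 1.5-fold higher number from compound 1 to compound 4 (0.18 log units; within the scatter) in this assay.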

Compound 4, half-maximal inhibitory concentration: 3000 nM
For compound 4 the middle estimate is 5.0-fold (0.70 log units) below the measured one; low and high end bracket the measured number.
By their numbers in this assay, from the lowest: compounds 2, 3 and 1 (each within the scatter of the next, the first and the last beyond it); then compound 4.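

Compound 1, compound 2 and compound 3 all carry 2-(1H-imidazol-1-yl)ethoxy, so only compound 4 tests this position, on a six-membered aromatic ring of carbon only. In this assay, ethoxycarbonyl in its place brings a 7.5-fold higher number from compound 1 to compound 4 (0.88 log units; beyond the scatter), which shows that the number responds to a change here as well as to the aryl group elsewhere on the shared core. Nothing available accounts for this step.

The single change removes a ring and also alters the size of the group, so the compounds shown do not separate the part played by the imidazole ring from that of its ethoxy chain. They leave open how a plain ethoxy, an amine-bearing chain or a carboxylic acid would read at this position, and whether ethoxycarbonyl would have a similar effect with thiophen-2-yl or furan-2-yl in place of pyridin-2-yl.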